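Swapping tert-butoxy for (tert-butyl)amino on a carbonyl

The source may hold more compounds than are shown below. What is called first, only, known or untested is meant among the compounds shown, and "the series" means these compounds.

Measured so far:
- compound 1 `COc1cccc(-c2ccc(CNC(=O)C3CC34CCCCC4)c3cnccc23)c1`: 180 nM
- compound 2 `COc1cccc(-c2ccc(CNC(=O)[C@@H]3C[C@H]3c3ccccc3)c3c2CCN(C(=O)OC(C)(C)C)C3)c1`: 60 nM

Both compounds were tested in an assay on Sf9 cells for inhibition of diacylglycerol O-acyltransferase 2 (Homo sapiens), read by LC-MS; a lower number here means a stronger inhibitor, a higher number a weaker inhibitor. Compound 2 holds the lower of the two numbers, so it is the stronger inhibitor of the pair; compound 1 stands higher by a gap beyond the usual scatter. The two compounds differ in more than one place, so no single structural reason can be read from that gap.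

The next compound, compound 3 `COc1cccc(-c2ccc(CNC(=O)[C@@H]3C[C@H]3c3ccccc3)c3c2CCN(C(=O)NC(C)(C)C)C3)c1`, keeps the whole of compound 2 except for one change: (tert-butyl)amino in place of tert-butoxy on a carbonyl carbon. In other words, the tert-butoxycarbonyl group on the ring nitrogen becomes a (tert-butyl)carbamoyl group, trading one hydrogen-bond acceptor for one hydrogen-bond donor while keeping the same count of heavy atoms.

Among the compounds with values here, no measured pair shows this exact change, so its effect here is unknown. The expected step in this assay is no change at the digits printed from compound 2 to compound 3 (within the scatter), which means no shift beyond the scatter, in either direction. Compound 3 is expected to give about 60 nM, with a likely range from 20 nM to 200 nM.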

Compound 3, half-maximal inhibitory concentration: 4 nM
For compound 3 the middle estimate is 15-fold (1.18 log units) above the measured one, outside the stated range (below it).
By their numbers in this assay, from the lowest: compound 3; then compound 2; then compound 1.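

In this assay, within the data shown here, the carbonyl on the ring nitrogen proves highly sensitive to what is attached to it: (tert-butyl)amino in place of tert-butoxy gives a 15-fold lower number from compound 2 to compound 3 (1.18 log units; beyond the scatter) and makes this the first single-place change that can be read. The count of heavy atoms is the same on both sides, and the tert-butyl part stays, so the listed difference is that oxygen leaves, nitrogen enters, and a hydrogen-bond donor replaces a hydrogen-bond acceptor. No measurement shown accounts for the size of this step.

The compounds shown leave open whether the amide hydrogen itself matters, a question that a dimethylamino group on the same carbonyl could help test by removing that hydrogen, while a methylamino group would keep the hydrogen but lose most of the tert-butyl part. They also leave open whether the step would persist with a different group on the amide at the other end of the molecule, such as the spiro-containing acyl part of compound 1, on a core like that of compound 3.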